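Amide-Nitrogen Variation in a Paw Edema Series

A few compounds are considered here, and "the series" means these few. Any claim that something is new, unique, unknown or untested is made for them only; others in the source may bear on it.

Measured so far:
compound 1, `O=C(Nc1ccccn1)c1c(O)c2cccnc2n(-c2ccccc2)c1=O`: -13.5%
compound 2, `CNC(=O)c1c(O)c2cccnc2n(-c2ccccc2)c1=O`: 9.6%

In a functional assay on the whole organism for inhibition, with Rattus norvegicus as the target, read by paw edema, at a dose of 100 mg/kg by the oral route (on this read-out lower numbers stand for less inhibition and higher numbers for more inhibition at the one dose given (going by the name of the read-out)), compound 1 gives -13.5% and compound 2 gives 9.6%. Within the data shown here, compound 2 stands highest of the two numbers; the single step that separates it from compound 1, a number 23.1 percentage points higher from compound 1 to compound 2 (beyond the scatter), lies beyond the scatter and is the only measured step. Compound 3, `CCCCNC(=O)c1c(O)c2cccnc2n(-c2ccccc2)c1=O`, differs from compound 2 as follows: propyl in place of hydrogen on a saturated chain carbon bound to an amide-type nitrogen. The step from compound 1 to compound 2 also concerns the substituent on the amide-type nitrogen, but it exchanges pyridin-2-yl for methyl, whereas the step to compound 3 lengthens methyl to butyl; it is therefore only a loose guide, and nothing measured separates methyl from butyl. With both measured numbers small and a single step known, no change beyond the scatter is expected on going from compound 2 to compound 3. The estimate for compound 3 in this assay is 12%, with a range from -8% to 32%. The step this implies, a number 2.4 percentage points higher from compound 2 to compound 3 (within the scatter), is expected to stay within the scatter.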

Compound 3, a percentage reported as inhibition, in the whole organism at one dose (the size of the read-out at that dose, not a potency): 12.8%
For compound 3 the middle estimate is 0.8 percentage points below the measured one; low and high end bracket the measured number.
By their numbers in this assay, from the lowest: compound 1; then compounds 2 and 3 (each within the scatter of the next).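

In this assay, among these compounds, going from methyl to butyl on the amide-type nitrogen gives a number 3.2 percentage points higher from compound 2 to compound 3 (within the scatter) and so leaves the read-out unresolved for these two chain lengths, which is the first information on chain length at this position. Replacing pyridin-2-yl with butyl gives a number 26.3 percentage points higher from compound 1 to compound 3 (beyond the scatter) at the same nitrogen, and read with a number 23.1 percentage points higher from compound 1 to compound 2 (beyond the scatter) in the same assay, this shows that the gap from pyridin-2-yl is not particular to methyl but holds for both saturated chains shown. Nothing measured here bears on why pyridin-2-yl stands apart from these two chains.

Still open, going by these compounds, is whether a longer chain such as octyl, a branched chain such as isopropyl, or a chain ending in an amine or a carboxylic acid would move the number beyond the scatter from compound 2 and compound 3. Also open, on these data alone, is whether phenyl on the same nitrogen would read like pyridin-2-yl or like the saturated chains, which would show whether the separation of compound 1 extends to other aromatic rings.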